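The source may report more compounds than this note shows. Statements on the series, on what has been measured and on what is new or still open speak of the compounds shown alone.

In an assay on Sf9 cells for inhibition of protein deacetylase HDAC6 (Homo sapiens), read by fluorescence, with a stated time of 40 min, tested at 100 nM (a lower number here means less inhibition, a higher number more inhibition at the concentration tested (going by the name of the read-out)), compound 3 `Cc1ccc(-c2nc(CNc3ccc(C(=O)NO)cc3)n(-c3ccccc3)n2)s1` gives 79.7%, the highest of the three numbers seen so far. Compound 2 `O=C(NO)c1ccc(NCc2nc(-c3ccc(F)cc3)nn2-c2ccccc2)cc1` gives 70.9%, and compound 1 `O=C(NO)c1ccc(NCc2nc(-c3ccc(Br)cc3)nn2-c2ccccc2)cc1` gives 54.7%. The step of a number 25 percentage points higher from compound 1 to compound 3 (beyond the scatter) lies beyond the scatter, whereas a number 8.8 percentage points higher from compound 2 to compound 3 (within the scatter) does not, so compound 3 and compound 2 cannot be told apart. Compound 4 `CC(C)c1ccc(-c2nc(CNc3ccc(C(=O)NO)cc3)n(-c3ccccc3)n2)cc1` differs from compound 3 in one place: 4-isopropylphenyl in place of 5-methylthiophen-2-yl on an aromatic carbon. Among the measured compounds shown here, the steps that bear on this change are the two exchanges of the group at the same position, a number 25 percentage points higher from compound 1 to compound 3 (beyond the scatter) and a number 8.8 percentage points higher from compound 2 to compound 3 (within the scatter), together with a number 16.2 percentage points higher from compound 1 to compound 2 (beyond the scatter), which shows that even a small change on that group can move the number. None of them involves 4-isopropylphenyl, so the direction is uncertain; in the pairs measured, a six-membered aromatic ring of carbon only at this place gave lower numbers than the thiophene. A modest drop, a number 14.7 percentage points lower from compound 3 to compound 4 (beyond the scatter), is therefore expected, and for compound 4 the estimated value is 65%, with a range from 40% to 85%.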

Compound 4, a percentage reported as inhibition, at one concentration (the size of the read-out at that concentration, not a potency): 27.6%
Beside the measured number, compound 4's estimate is 37.4 percentage points above it, and the stated range ends above it.
By their numbers in this assay, from the lowest: compound 4; then compound 1; then compounds 2 and 3 (each within the scatter of the next).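

In this assay, among the compounds shown here, the group on the aromatic carbon between two ring nitrogen atoms proves far less forgiving than the earlier compounds showed, with a number 52.1 percentage points lower from compound 3 to compound 4 (beyond the scatter), the largest step seen at this position so far. Against the halogen-bearing phenyl compounds, isopropyl also gives lower numbers, with a number 43.3 percentage points lower from compound 2 to compound 4 (beyond the scatter) and a number 27.1 percentage points lower from compound 1 to compound 4 (beyond the scatter), so among these three the number falls from fluoro to bromo to isopropyl. Nothing available here explains these drops.

From the compounds shown here alone, it remains open whether the loss is specific to isopropyl or would also appear with a methyl, methoxy, amine or carboxylic acid group on that phenyl ring. A 4-methylphenyl group or an unsubstituted thiophene would help separate the contribution of the ring from that of its substituent.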